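Series notes: the step from compound 2 to compound 3

The source may report more compounds than this note shows. Statements on the series, on what has been measured and on what is new or still open speak of the compounds shown alone.

Two members of the series have been measured in a functional assay on NCI-H23 cells (Homo sapiens) for cytotoxicity, read by sulforhodamine B assay, tested at 10 uM; a higher number here means more inhibition at the concentration tested (going by the name of the read-out), a lower number less inhibition. Compound 1 `CCCc1cc(-c2cn([C@H]3C[C@H](OC(C)=O)[C@@H](COC(C)=O)O3)c(=O)[nH]c2=O)on1` gives 96.9% in this assay. Compound 2 `CC(=O)OC[C@H]1O[C@@H](n2cc(-c3cc(-c4ccc(C(C)C)cc4)no3)c(=O)[nH]c2=O)C[C@@H]1OC(C)=O` gives 108% in this assay. Among the measured compounds shown here, the single measured step, a number 11.1 percentage points higher from compound 1 to compound 2 (beyond the scatter), exchanges propyl for 4-isopropylphenyl on an aromatic carbon and moves the read-out beyond the scatter. On the two numbers at hand compound 2 stands highest, with compound 1 as its nearest neighbour, lower by an amount beyond the scatter.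

Compound 3 `CCCCc1ccc(-c2cc(-c3cn([C@H]4C[C@H](OC(C)=O)[C@@H](COC(C)=O)O4)c(=O)[nH]c3=O)on2)cc1` is not yet measured. It differs from compound 2 thus: butyl in place of isopropyl on an aromatic carbon Cut one bond further out, the change reads 4-isopropylphenyl to 4-butylphenyl. For the measured compounds named here, no measured step varies the group on the six-membered aromatic ring of carbon only; the one step that exists, a number 11.1 percentage points higher from compound 1 to compound 2 (beyond the scatter), concerns the whole 4-isopropylphenyl group and bears only indirectly. With compound 2 already at 108%, little room remains upward. Compound 3 is therefore expected to read 102%, within 88% to 112%, the expected step of a number 6 percentage points lower from compound 2 to compound 3 (within the scatter) lying within the scatter.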

Compound 3, a percentage reported as inhibition, at one concentration (the size of the read-out at that concentration, not a potency): 97.4%
For compound 3 the middle estimate is 4.6 percentage points above the measured one; low and high end bracket the measured number.
By their numbers in this assay, from the lowest: compounds 1 and 3 (each within the scatter of the next); then compound 2.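

In this assay, the group on the six-membered aromatic ring of carbon only now has a measured effect of its own: butyl in place of isopropyl gives a number 10.6 percentage points lower from compound 2 to compound 3 (beyond the scatter), so the read-out responds to the alkyl group at this position and not only to the presence of the aryl group. The rise seen with 4-isopropylphenyl therefore does not extend to 4-butylphenyl, since 4-butylphenyl in place of propyl gives a number 0.5 percentage points higher from compound 1 to compound 3 (within the scatter), leaving compound 2 as the only one of the three that stands apart. Nothing at hand explains the difference between isopropyl and butyl at this position.

With only these two groups on the ring, the effect of branching cannot be separated from that of chain length, and a tert-butyl group, a longer hexyl chain, a methoxy group or a carboxylic acid in the same place would test how narrow the preference is. Readings at a single concentration also leave open how compounds 1, 2 and 3 would rank at lower concentrations.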